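The source may hold more compounds than are shown below. What is called first, only, known or untested is meant among the compounds shown, and "the series" means these compounds.

Measured in a functional assay on K562 cells (Homo sapiens) for antiproliferative activity, read by trypan blue exclusion, with a stated time of 48 h, tested at 10 uM; on this read-out lower numbers stand for less inhibition of growth and higher numbers for more inhibition of growth at the one concentration tested:

Compound 1 `NC(=O)c1cc(Br)ccc1NC(=O)/C=C/c1ccccc1` gives 62.4%
Compound 2 `Cc1cccc(/C=C/C(=O)Nc2ccc(Br)cc2C(N)=O)c1` gives 43.8%
Compound 3 `Cc1ccc(/C=C/C(=O)Nc2ccc(Br)cc2C(N)=O)cc1` gives 45.9%

Compound 3 sits within the scatter of compound 2 and clearly short of compound 1, with a number 16.5 percentage points lower from compound 1 to compound 3 (beyond the scatter). Among the compounds with values here, compound 4 `Cc1ccc(/C=C/C(=O)Nc2ccc(I)cc2C(N)=O)cc1` carries iodo in place of bromo on an aromatic carbon, the only difference from compound 3 (iodo in place of bromo on an aromatic carbon).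

Within the data shown here, no measured step exchanges this halogen, so the evidence is indirect. Methyl in place of hydrogen on an aromatic carbon gave modest steps, a number 18.6 percentage points lower from compound 1 to compound 2 (beyond the scatter) and a number 16.5 percentage points lower from compound 1 to compound 3 (beyond the scatter). Moving that methyl gave a number 2.1 percentage points higher from compound 2 to compound 3 (within the scatter), within the scatter. None of these steps touches the bromo, so they give no direction for the exchange, and the expectation rests on compound 3 at 45.9%. In this assay the expected a number 0.1 percentage points higher from compound 3 to compound 4 (within the scatter) stays within the scatter. Compound 4 is estimated at 46%, with an expected range from 32% to 60%.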

Compound 4, percent growth inhibition at one concentration: 26.3%
Compound 4: the middle estimate sits 19.7 percentage points above what was measured; the whole stated range lies above it.
By their numbers in this assay, from the lowest: compound 4; then compounds 2 and 3 (each within the scatter of the next); then compound 1.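

Within the data shown here, the position meta to a carbamoyl group and para to a large group proves sensitive in this assay: iodo in place of bromo gives a number 19.6 percentage points lower from compound 3 to compound 4 (beyond the scatter), the first step in this set to touch the halogen rather than a methyl group. The change is small by the computed counts, since each group is a single heavy atom with no hydrogen-bond donors or acceptors and no net charge, so those counts do not separate the two. Nothing measured here accounts for the step.

Among these compounds, whether the same exchange would move compound 1 in the same way remains open, since iodo is seen only with the 4-methylphenyl group. Also open, going by these compounds, is how a chloro, a fluoro or an amine at this position would compare with bromo and iodo.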